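Dichlorophenyl replacing dimethoxyphenyl in a hydrazone urea series

The source may report more compounds than this note shows. Statements on the series, on what has been measured and on what is new or still open speak of the compounds shown alone.

The measured compounds are:

Compound 1 `CN(C)CCn1cnnc1-c1cc(Oc2ccc(NC(=O)N/N=C/c3cccc(Cl)c3Cl)cc2F)ccn1`: 130 nM
Compound 2 `CN(C)CCn1cnnc1-c1cc(Oc2ccc(NC(=O)N/N=C/c3ccc(O)c(Br)c3)cc2F)ccn1`: 450 nM
Compound 3 `COc1ccc(/C=N/NC(=O)Nc2ccc(Oc3ccnc(-c4nncn4CCN(C)C)c3)c(F)c2)c(OC)c1`: 1780 nM

In a functional assay on HT-29 cells (Homo sapiens) for cytotoxicity, read by MTT assay, with a stated time of 72 h (a lower number here means a stronger inhibitor, a higher number a weaker inhibitor), compound 3 gives the highest number of the three; the nearest is compound 2, with a 4.0-fold higher number from compound 2 to compound 3 (0.60 log units; beyond the scatter) between them, and the furthest is compound 1, with a 14-fold higher number from compound 1 to compound 3 (1.14 log units; beyond the scatter). Compound 4 `CN(C)CCn1cnnc1-c1cc(Oc2ccc(NC(=O)N/N=C/c3ccc(Cl)cc3Cl)cc2F)ccn1` has not yet been measured. It differs from compound 3 in one place: 2,4-dichlorophenyl in place of 2,4-dimethoxyphenyl on a carbon with a double bond to nitrogen.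

For the measured compounds named here, the step that bears most directly on this change is the one leading from compound 1, which carries a 2,3-dichlorophenyl group on the same carbon, to compound 3: a 14-fold higher number from compound 1 to compound 3 (1.14 log units; beyond the scatter). Compound 4 reverses the aromatic substitution pattern toward chlorine again, though at the 2,4-positions rather than the 2,3-positions, so a large fall in the number is expected, roughly undoing that step. Compound 4 is estimated at 200 nM (range 70 nM to 600 nM), which means an expected step of an 8.9-fold lower number from compound 3 to compound 4 (0.95 log units; beyond the scatter).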

Compound 4, half-maximal inhibitory concentration: 390 nM
For compound 4 the middle estimate is 2.0-fold (0.29 log units) below the measured one; measured number inside the range.
By their numbers in this assay, from the lowest: compound 1; then compounds 4 and 2 (each within the scatter of the next); then compound 3.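

In this assay the placing of the chlorine atoms matters on this carbon with a double bond to nitrogen: 2,4-dichlorophenyl in place of 2,3-dichlorophenyl gives a 3.0-fold higher number from compound 1 to compound 4 (0.48 log units; beyond the scatter) and so does not match the earlier dichlorophenyl compound. Chlorine in place of methoxy, with the substitution positions kept, still gives a 4.6-fold lower number from compound 3 to compound 4 (0.66 log units; beyond the scatter) and so lowers the number, though less than the step from compound 1 to compound 3 might have suggested. Against 3-bromo-4-hydroxyphenyl there is a 1.2-fold lower number from compound 2 to compound 4 (0.06 log units; within the scatter) and thus no separation, and no measurement shown accounts for any of these steps.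

What the compounds shown leave open is how a ring with a single chlorine, a nitrile or an amine would compare on this carbon. They also leave open whether the gap between the two dichlorophenyl groups would hold on another cell line.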